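Reversing a large amide change at the carbonyl

This account rests on a few compounds, and the source may have more. Where it says the series, first, only, none or still open, it means among the compounds named here.

Measured compounds in a functional assay on MIA PaCa-2 cells (Homo sapiens) for inhibition, read by MTT assay, with a stated time of 7 days; on this read-out higher numbers stand for weaker inhibition and lower numbers for stronger inhibition:
compound 1, `CCN(CC)S(=O)(=O)c1ccc(S(=O)(=O)N2CCC[C@@H](C(=O)NC3COC3)C2)cc1`, 2340 nM
compound 2, `CCN(CC)S(=O)(=O)c1ccc(S(=O)(=O)N2CCC[C@@H](C(=O)N[C@H]3CCOC3)C2)cc1`, 1670 nM
compound 3, `CCN(CC)S(=O)(=O)c1ccc(S(=O)(=O)N2CCC[C@@H](C(=O)N3CCC(F)(F)CC3)C2)cc1`, 16 nM

Compound 3 gives the lowest number of the three, and its steps to the others are beyond the scatter. Compound 4, `CCN(CC)S(=O)(=O)c1ccc(S(=O)(=O)N2CCC[C@@H](C(=O)N[C@@H]3CCOC3)C2)cc1`, differs from compound 3 by (oxolan-3-yl)amino in place of 4,4-difluoropiperidin-1-yl on a carbonyl carbon. The measured steps that bear on this are the ones that made the opposite change: a 100-fold lower number from compound 2 to compound 3 (2.02 log units; beyond the scatter) and a 150-fold lower number from compound 1 to compound 3 (2.17 log units; beyond the scatter). Both were large and in the same direction, so the move from compound 3 to compound 4 is expected to go the other way by a similar amount, toward a higher number in this assay. For the measured compounds named here, compound 4 carries the oxolan-3-yl group with one defined stereocentre, and no measured step tells how much that alone matters; this widens the range. The estimate for compound 4 is a number near 1700 nM, between 500 nM and 6000 nM, which corresponds to a step of a 110-fold higher number from compound 3 to compound 4 (2.03 log units; beyond the scatter).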

Compound 4, half-maximal inhibitory concentration: 750 nM
Compound 4: middle estimate off by 2.3-fold (0.36 log units), on the high side, and the stated range covers the measured number.
By their numbers in this assay, from the lowest: compound 3; then compound 4; then compounds 2 and 1 (each within the scatter of the next).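

In this assay, the configuration of the oxolan-3-yl group matters on its own (a 2.2-fold lower number from compound 2 to compound 4 (0.35 log units; beyond the scatter)), and this step can be read as a stereochemical one: the fact that compounds 2 and 4 differ only in the configuration as drawn. Even so, the 4,4-difluoropiperidin-1-yl amide remains well ahead of the oxolan-3-yl amide in its better configuration (a 47-fold higher number from compound 3 to compound 4 (1.67 log units; beyond the scatter)), so the large gap persists with either oxolan-3-yl configuration. Compound 4 also separates from the oxetan-3-yl amide (a 3.1-fold lower number from compound 1 to compound 4 (0.49 log units; beyond the scatter)), whereas compound 2 does not (a 1.4-fold lower number from compound 1 to compound 2 (0.15 log units; within the scatter)), so oxolan-3-yl differs from oxetan-3-yl here in only one of its two configurations.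

From the compounds shown here alone, the fluorines and the amide hydrogen change together in these compounds, so their separate contributions remain open. A piperidin-1-yl amide without fluorine and an oxolan-3-yl amide carrying a methyl group on its nitrogen would each address one of these questions.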